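The compounds below may be only part of what the source reports. "The series", "measured", "known", "first", "only" and "open" are said of these compounds alone.

In a functional assay (aorta) for inhibition, with Rattus norvegicus as the target (a lower number here means that less compound is needed, a higher number that more compound is needed for the effect), compound 1 `O=C1C(Nc2ccc(F)cc2)=CC(=O)c2ncccc21` gives 541 nM, while compound 2 `O=C1C(Nc2ccc(I)cc2)=CC(=O)c2ncccc21` gives 214 nM, the lower of the two numbers. Compound 3 `O=C1C(Nc2ccc(C(F)(F)F)cc2)=CC(=O)c2ncccc21` differs from compound 2 by trifluoromethyl in place of iodo on an aromatic carbon, with trifluoromethyl in place of iodo on an aromatic carbon. Among the measured compounds shown here, only one measured step bears on this place, the modest 2.5-fold lower number from compound 1 to compound 2 (0.40 log units; beyond the scatter), with iodo in place of fluoro. A step of similar modest size toward a higher number is therefore expected, and the estimated change is a 1.5-fold higher number from compound 2 to compound 3 (0.17 log units; within the scatter). The expected value for compound 3 is 320 nM, within an estimated range of 130 nM to 800 nM.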

Compound 3, half-maximal effective concentration: 607 nM
Compound 3: middle estimate off by 1.9-fold (0.28 log units), on the low side; low and high end bracket the measured number.
By their numbers in this assay, from the lowest: compound 2; then compounds 1 and 3 (each within the scatter of the next).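

In this assay, trifluoromethyl in place of iodo on this aromatic carbon gives a 2.8-fold higher number from compound 2 to compound 3 (0.45 log units; beyond the scatter), so the earlier gain with iodo is lost with this group. Trifluoromethyl in place of fluoro gives a 1.1-fold higher number from compound 1 to compound 3 (0.05 log units; within the scatter), which lies within the scatter, so among these three compounds only compound 2 stands apart. Nothing available here explains why iodo differs from the other two groups. Going by these compounds, it remains open whether chloro or bromo would give a number like that of compound 2, and how an amine or a carboxylic acid would read at this place.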